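The compounds below may be only part of what the source reports. "The series", "measured", "known", "first", "only" and "open" are said of these compounds alone.

Measured in an ADME assay on Huh-7 cells (Homo sapiens) for cytotoxicity, with a stated time of 72 h; on this read-out lower numbers stand for higher toxicity in this test and higher numbers for lower toxicity in this test:
Compound 1 `CC(C)CCn1nc(-c2cccs2)c(O)c(C2=NS(=O)(=O)c3cc(S(C)(=O)=O)ccc3N2)c1=O`: "not determined" (no result reported)
Compound 2 `CS(=O)(=O)Nc1ccc2c(c1)S(=O)(=O)N=C(c1c(O)c(-c3ccsc3)nn(CCC3CC3)c1=O)N2`: > 1000 nM
Compound 3 `CC(C)CCn1nc(-c2ccn(C)c2)c(O)c(C2=NS(=O)(=O)c3cc(NS(C)(=O)=O)ccc3N2)c1=O`: > 1000 nM

The numbers shown give little to work with. Compound 2 gives > 1000 nM, which is a limit of this assay and not a number. Compound 3 gives > 1000 nM, which is likewise a limit. Compound 1 has no reported result, so the whole picture comes down to the limit of > 1000 nM in this assay, at which 2 of the 3 values shown sit. Compound 2 therefore has a lower bound but no exact position.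

The next compound to be tested is compound 4 `CS(=O)(=O)Nc1ccc2c(c1)S(=O)(=O)N=C(c1c(O)c(-c3ccc(Cl)s3)nn(CCC3CC3)c1=O)N2`. It has 5-chlorothiophen-2-yl in place of thiophen-3-yl on an aromatic carbon, ortho to a hydroxy group (5-chlorothiophen-2-yl in place of thiophen-3-yl on an aromatic carbon). The rest of the structure is that of compound 2.

Going by the values given here, no two measured compounds differ in one place only, so the data give no measured size for a change of this kind. The expectation is therefore modest, with no shift beyond the usual scatter in either direction. The expected step is a step that the limit leaves unreadable from compound 2 to compound 4. A report of only a limit is the likeliest outcome for compound 4, as it was for compound 2 with > 1000 nM. For compound 4 the estimate is 1500 nM, with an expected range from 600 nM to 10000 nM.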

Compound 4, half-maximal cytotoxic concentration: > 33000 nM
Compound 4: only a limit was reported; the forecaster's own chance of this, stated with the estimate: 80%; at least 22-fold (1.34 log units) between middle value and limit.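

In this assay compound 4 gives > 33000 nM, which is a limit of the assay and not a number. Compound 2 gives > 1000 nM, likewise a limit, so the step between compound 2 and compound 4 cannot be read. The compounds shown leave open what effect, if any, 5-chlorothiophen-2-yl in place of thiophen-3-yl has on this read-out.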